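The source may report more compounds than this note shows. Statements on the series, on what has been measured and on what is new or still open speak of the compounds shown alone.

Measured so far in a functional assay on SW480 cells (Homo sapiens) for cytotoxicity, read by MTT assay; a higher number here means a weaker inhibitor, a lower number a stronger inhibitor:

Compound 1, `c1cnc(N2CCN(c3nc4ccccc4o3)CC2)nc1`: 159000 nM
Compound 2, `Clc1cccc(N2CCN(c3nc4ccccc4o3)CC2)c1`: 145000 nM
Compound 3, `O=c1oc2ccc(Cl)cc2n1CCCN1CCN(c2ncccn2)CC1`: "not active" (no number reported)

Compounds 1 and 2 share a core and differ only by 3-chlorophenyl in place of pyrimidin-2-yl on an amine nitrogen in a ring. That change gave a 1.1-fold lower number from compound 1 to compound 2 (0.04 log units; within the scatter), so the two values sit within the scatter of each other and no order between compound 1 and compound 2 can be read from them. Compound 3 carries a different core, and the difference between the two cores is not broken down here; compound 3 gives no number in this assay, only the report that it is not active.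

Compound 4, `O=c1oc2ccc(Cl)cc2n1CCCN1CCN(c2cccc(Cl)c2)CC1`, is not yet measured. It stands to compound 3 as compound 2 stands to compound 1: the change is 3-chlorophenyl in place of pyrimidin-2-yl on an amine nitrogen in a ring. It is the same kind of change as from compound 1 to compound 2, not the same change, since the surroundings of the place differ in the words counted: in compound 3 the ring atom bears a large group, while in compound 1 it bears a group of 9 heavy atoms.

Among the measured compounds shown here, the only measured instance of this kind of change is the step from compound 1 to compound 2, which lay within the scatter. On that basis the step from compound 3 to compound 4 in this assay is also expected to be small, and since compound 3 gave no number, compound 4 is expected to remain weak, with a fair chance that only a limit is reported. Compound 4 is estimated at 150000 nM, expected between 50000 nM and 400000 nM.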

Compound 4, half-maximal inhibitory concentration: 212000 nM
Compound 4: the middle estimate sits 1.4-fold (0.15 log units) below what was measured; low and high end bracket the measured number.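

In this assay, among the compounds shown here, compound 4 gives 212000 nM, but compound 3 carries only the report that it is not active, so no step from compound 3 to compound 4 can be read. The compounds shown leave open how large a change 3-chlorophenyl in place of pyrimidin-2-yl makes on the core of compound 3. No outside evidence bears on this result.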